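The source may hold more compounds than are shown below. What is called first, only, known or untested is meant among the compounds shown, and "the series" means these compounds.

Measured so far in a physicochemical assay for solubility, in phosphate buffer, at pH 7.4; on this read-out higher numbers stand for higher solubility and lower numbers for lower solubility:
- compound 1 `OC1CCN(c2nccnc2OC2CN(c3ccc4ccccc4n3)C2)CC1` at 99000 nM
- compound 2 `CN(C)C1CCN(c2nccnc2OC2CN(c3ccc4ccccc4n3)C2)CC1` at 500000 nM

Compound 2 stands highest of these two numbers, and compound 1 is its nearest neighbour. The next step leads to compound 3 `N#CC1CCN(c2nccnc2OC2CN(c3ccc4ccccc4n3)C2)CC1`, with cyano in place of dimethylamino on a saturated ring carbon and the rest of the structure unchanged.

Among the compounds with values here, one measured step bears on this change. It is a 5.1-fold higher number from compound 1 to compound 2 (0.70 log units; beyond the scatter) with dimethylamino in place of hydroxy on a saturated ring carbon, a modest step but beyond the scatter. Within the data shown here, this is a single pair, and no measured compound carries cyano, so the data say more about direction than about size. With dimethylamino gone, a lower number is expected in this assay, by a step somewhat larger than the one measured, though this is uncertain. The expected step is an 11-fold lower number from compound 2 to compound 3 (1.05 log units; beyond the scatter) and rests on that one pair alone. The estimated value for compound 3 is 45000 nM with an expected range from 14000 nM to 140000 nM.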

Compound 3, solubility: 66000 nM
Estimate against measurement, compound 3: 1.5-fold (0.17 log units) below; the range from low to high includes it.
By their numbers in this assay, from the lowest: compounds 3 and 1 (each within the scatter of the next); then compound 2.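

At the saturated ring carbon three ring bonds from the ring nitrogen, this assay now compares three groups, and replacing dimethylamino with cyano gives a 7.6-fold lower number from compound 2 to compound 3 (0.88 log units; beyond the scatter) as a second step out of compound 2. Cyano in place of hydroxy gives a 1.5-fold lower number from compound 1 to compound 3 (0.18 log units; within the scatter) so these two groups cannot be told apart on this read-out, while dimethylamino alone stands apart, and none of the three compounds goes against that. No evidence on the cause of these differences is at hand.

Still open, on these data alone, is whether the higher number belongs to dimethylamino specifically or would also appear with another amine at this place, such as a primary amine or a morpholine, and how a carboxylic acid or a longer chain would read there. Also open is whether the differences among these three groups hold on a core other than the one shared here, since all three compounds carry the same remainder of the structure.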